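The compounds below may be only part of what the source reports. "The series", "measured", "known", "first", "only" and "open" are said of these compounds alone.

Measured in a functional assay on Caco-2 cells (Homo sapiens) for inhibition, read by MTT assay, with a stated time of 48 h, tested at 10 uM; on this read-out lower numbers stand for less inhibition of growth and higher numbers for more inhibition of growth at the one concentration tested:
Compound 1 `Cc1cc(=O)c2c(O)cc(OCc3ccco3)c([C@H]3CCN(C)C[C@H]3O)c2o1`: 17%
Compound 2 `Cc1cc(=O)c2c(O)c(CN3CCCC3)c(O)c([C@H]3CCN(C)C[C@H]3O)c2o1`: 22%
Compound 3 `Cc1oc2c([C@H]3CCN(C)C[C@H]3O)c(O)cc(O)c2c(=O)c1C(O)c1ccc([N+](=O)[O-])cc1`: 5%

Compound 3 has the lowest of the three numbers, and compound 1 and compound 2 both stand above it, beyond the scatter. Compound 4 `Cc1oc2c([C@H]3CCN(C)C[C@H]3O)c(O)cc(O)c2c(=O)c1C(O)c1csc([N+](=O)[O-])c1` has not yet been measured. It carries 5-nitrothiophen-3-yl in place of 4-nitrophenyl on a saturated chain carbon bound to an aromatic carbon and an oxygen on a saturated carbon. Going by the values given here, no measured pair here differs in one place only, so the data offer no direct guide to this swap. Both groups are nitro-bearing aromatic rings, so no step beyond the scatter is expected in this assay. The expected step is a number 3 percentage points higher from compound 3 to compound 4 (within the scatter). For compound 4 the estimated value is 8%, with an expected range from 0% to 22%.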

Compound 4, percent growth inhibition at one concentration: 3%
Estimate against measurement, compound 4: 5 percentage points above; measured number inside the range.
By their numbers in this assay, from the lowest: compounds 4 and 3 (each within the scatter of the next); then compounds 1 and 2 (each within the scatter of the next).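

Going by these compounds alone, putting 5-nitrothiophen-3-yl in place of 4-nitrophenyl in this assay gives a number 2 percentage points lower from compound 3 to compound 4 (within the scatter), the first comparison here of compounds that differ in one place only. At this position, a five-membered aromatic ring with a sulfur atom and a six-membered all-carbon aromatic ring, each bearing a nitro group, therefore cannot be told apart in this read-out. No measured evidence bears on why. The compounds shown leave open what an amine or a carboxylic acid in place of the nitro group would do on either ring.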